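Working notes: amine variation on the thiocarbonyl carbon

The compounds below may be only part of what the source reports. "The series", "measured", "known", "first", "only" and "open" are said of these compounds alone.

Measured in a functional assay on MGC-803 cells (Homo sapiens) for antiproliferative activity, read by CCK-8 assay, with a stated time of 72 h, tested at 2 uM; a lower number here means a weaker effect, a higher number a stronger effect of the compound at the concentration tested:
compound 1 `COc1ccc(N2CCN(C(=S)SCc3ccc(C(=O)Nc4ccccc4N)cc3)CC2)cc1` — 25.3%
compound 2 `Nc1ccccc1NC(=O)c1ccc(CSC(=S)N2CCc3cc(Cl)ccc32)cc1` — 57.7%
compound 3 `Nc1ccccc1NC(=O)c1ccc(CSC(=S)N2CCN(c3ncccn3)CC2)cc1` — 28.4%

Compound 2 stands highest of the three numbers; compound 3 is nearest and compound 1 furthest, both beyond the scatter. Among the measured compounds shown here, the only measured step, a number 3.1 percentage points higher from compound 1 to compound 3 (within the scatter), lies within the scatter and changes the group on an amine nitrogen in a ring while keeping the ring amine on the thiocarbonyl carbon. The step to compound 4 `CN(Cc1cccnc1)C(=S)SCc1ccc(C(=O)Nc2ccccc2N)cc1` is different in kind: methyl((pyridin-3-yl)methyl)amino in place of 5-chloro-2,3-dihydro-1H-indol-1-yl on a thiocarbonyl carbon. For the measured compounds named here, no measured pair shows a ring amine replaced by an open-chain amine at this place, so the size of the step is uncertain; since compound 1 and compound 3 sit far below compound 2, a fall is expected, a number 22.7 percentage points lower from compound 2 to compound 4 (beyond the scatter). Compound 4 is estimated at 35%, between 18% and 55%.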

Compound 4, a percentage reported as inhibition, at one concentration (the size of the read-out at that concentration, not a potency): 45.9%
For compound 4 the middle estimate is 10.9 percentage points below the measured one; measured number inside the range.
By their numbers in this assay, from the lowest: compounds 1 and 3 (each within the scatter of the next); then compound 4; then compound 2.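

In this assay, methyl((pyridin-3-yl)methyl)amino in place of 5-chloro-2,3-dihydro-1H-indol-1-yl on a thiocarbonyl carbon gives a number 11.8 percentage points lower from compound 2 to compound 4 (beyond the scatter). An open-chain amine at this place therefore costs only a modest part of the read-out, so the ring amine of compound 2 is not required for activity at the concentration tested. Nothing available explains this step.

The two groups differ in several features at once, so the share of the chlorine and of the pyridin-3-yl remains unresolved. A dimethylamino group or an unsubstituted indoline at this place would begin to separate them.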